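Removing the Methyl from the Bromoalkyl Chain of Compound 1

This account rests on a few compounds, and the source may have more. Where it says the series, first, only, none or still open, it means among the compounds named here.

Compound 1 `Cc1ccc(NC(=O)C(C)Br)cc1C(=O)NC(N)=O` is tested in a functional assay on CCRF-CEM cells (Homo sapiens) for antiproliferative activity, read by trypan blue exclusion, with a stated time of 72 h; a lower number here means a stronger inhibitor, a higher number a weaker inhibitor. In this assay compound 1 reaches only the limit > 20000 nM. Among its relatives, compound 2 `CC(Br)C(=O)Nc1ccc(Cl)c(C(=O)NC(N)=O)c1` gives 2550 nM and compound 3 `CC(Br)C(=O)Nc1ccc(Br)c(C(=O)NC(N)=O)c1` gives 7630 nM in this assay; the steps of an at least 7.8-fold lower number from compound 1 to compound 2 (0.89 log units; beyond the scatter) and an at least 2.6-fold lower number from compound 1 to compound 3 (0.41 log units; beyond the scatter) both change the group on the aromatic ring, and a 3.0-fold higher number from compound 2 to compound 3 (0.48 log units; beyond the scatter) does as well. Compound 4 `Cc1ccc(NC(=O)CBr)cc1C(=O)NC(N)=O` differs from compound 1 in a different place: hydrogen in place of methyl on a saturated chain carbon bound to a bromine atom and a carbonyl carbon. For the measured compounds named here, none of the measured steps touches this saturated chain carbon, so the three aromatic steps give no guide to the direction or size of this change. The estimate for compound 4 is therefore 15000 nM, between 3000 nM and 50000 nM, which would mean an expected step of an at least 1.3-fold lower number from compound 1 to compound 4 (0.12 log units; that floor lies within the scatter).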

Compound 4, half-maximal inhibitory concentration: 4760 nM
Beside the measured number, compound 4's estimate is 3.2-fold (0.50 log units) above it, within the range that was stated.
By their numbers in this assay, from the lowest: compounds 2, 4 and 3 (each within the scatter of the next, the first and the last beyond it). At a limit, above all of these: compound 1.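

For the compounds shown here, replacing the 1-bromoethyl group with bromomethyl gives an at least 4.2-fold lower number from compound 1 to compound 4 (0.62 log units; beyond the scatter) in this assay, so this saturated chain carbon matters as well as the group on the aromatic ring, which was the only place changed in the earlier steps. On these data alone, the real size of this step stays unknown because compound 1 stands at a limit: the limit of > 20000 nM in this assay, at which 1 of the 4 values shown sits.

A longer chain on this carbon, or an amine in place of the bromine, remains untested among the compounds shown. Also open, as far as these compounds go, is whether this change gives a similar step when chloro or bromo sits on the aromatic ring.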